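Acylating the aniline nitrogen of compound 1

This account rests on a few compounds, and the source may have more. Where it says the series, first, only, none or still open, it means among the compounds named here.

Compound 1 `Cc1ccc(N)cc1S(=O)(=O)N(C)/N=C/c1cnn2ccc(C#N)cc12` is measured in an assay on isolated protein for inhibition of phosphatidylinositol 4,5-bisphosphate 3-kinase catalytic subunit beta isoform (Homo sapiens), read by 33P incorporation, with a stated time of 60 min (a higher number here means a weaker inhibitor, a lower number a stronger inhibitor), only as a limit, and in this assay compound 1 gives > 1000 nM. Compound 2 `CN(C)c1ccc([N+](=O)[O-])cc1S(=O)(=O)N(C)/N=C/c1cnn2ccc(C#N)cc12` is also measured, and in this assay compound 2 gives 44 nM. Compound 3 `Cc1ccc(NC(=O)C(F)(F)F)cc1S(=O)(=O)N(C)/N=C/c1cnn2ccc(C#N)cc12` differs from compound 1 in one place: (trifluoromethyl)carbonyl in place of hydrogen on a nitrogen on an aromatic ring. Among the measured compounds shown here, no measured step joins these compounds, so the size of the change is unknown; a modest move toward stronger inhibition is expected, as a step that the limit leaves unreadable from compound 1 to compound 3. Compound 3 is therefore estimated to give 1500 nM in this assay, with a range from 300 nM to 8000 nM.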

Compound 3, half-maximal inhibitory concentration: > 1000 nM
Compound 3 gave a limit, no number; the forecaster's own chance of this, stated with the estimate: 50%; the middle value lies beyond the limit too.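

No step can be read from compound 1 to compound 3, since both stand only as limits in this assay: the limit of > 1000 nM in this assay, at which 2 of the 3 values shown sit. From the compounds shown here alone, whether (trifluoromethyl)carbonyl in place of hydrogen on that nitrogen changes inhibition at all, and in which direction, stays open.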